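A few compounds are considered here, and "the series" means these few. Any claim that something is new, unique, unknown or untested is made for them only; others in the source may bear on it.

Compound 1 `ClCc1ccc(Cn2cnc3c(Cl)ncnc32)cc1` gives 1250 nM in a functional assay on U-251 cells (Homo sapiens) for cytotoxicity, read by sulforhodamine B assay, with a stated time of 48 h (on this read-out lower numbers stand for stronger inhibition of growth and higher numbers for weaker inhibition of growth), the lower of the two numbers recorded, though the gap to compound 2 `ClCc1cccc(Cn2cnc3c(Cl)nc(Cl)nc32)c1`, which gives 1690 nM in this assay, lies within the scatter. Compound 3 `ClCc1ccc(Cn2cnc3c(Cl)nc(Cl)nc32)cc1` has not yet been measured. It differs from compound 1 by chloro in place of hydrogen on an aromatic carbon. For the measured compounds named here, no measured pair shows this same change, so the size of the step is not known from the data; a step of no more than the scatter in this assay is expected, because compound 2 gives 1690 nM. For compound 3 the estimate is 1400 nM, expected to fall between 700 nM and 2800 nM, which means an expected step of a 1.1-fold higher number from compound 1 to compound 3 (0.05 log units; within the scatter).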

Compound 3, concentration for 50% growth inhibition: 2040 nM
The estimate for compound 3 lay 1.5-fold (0.16 log units) below the measured number; the range from low to high includes it.
By their numbers in this assay, from the lowest: compounds 1, 2 and 3 (each within the scatter of the next).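

In this assay, for the compounds shown here, the first measured pair for chloro in place of hydrogen on this aromatic carbon, between two ring nitrogen atoms, gives a 1.6-fold higher number from compound 1 to compound 3 (0.21 log units; within the scatter). In this one pair, the position therefore carries a chloro group without a step beyond the scatter. No measurement shown accounts for the size of this step. From the compounds shown here alone, it remains open whether an amine, a methoxy group or a longer chain on this same carbon would also stay within the scatter of compound 1. Going by these compounds, whether the chloro step would hold with other changes elsewhere on the core also remains open.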